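Replacing a Benzyl Amide by an Aryl Amide

The compounds below may be only part of what the source reports. "The series", "measured", "known", "first", "only" and "open" are said of these compounds alone.

Compound 3 `COc1ccc2c(=O)c(/C=C/C(=O)NCc3ccc(C)cc3)coc2c1` sits at the ceiling of a functional assay on HeLa cells (Homo sapiens) for inhibition, read by MTT assay, with a stated time of 48 h; on this read-out lower numbers stand for stronger inhibition and higher numbers for weaker inhibition: its value of > 100000 nM is a limit and not a number. Compound 2 `COc1ccc(CNC(=O)/C=C/c2coc3cc(OC)ccc3c2=O)cc1` likewise returns only a limit, > 100000 nM. Compound 1 `COc1ccc2c(=O)c(/C=C/C(=O)Nc3ccc(C)cc3)coc2c1`, by contrast, gives a reading of 24100 nM in this assay. The picture is shaped by the limit of > 100000 nM in this assay, at which 2 of the 3 values shown sit. The step of an at least 4.1-fold higher number from compound 1 to compound 3 (0.61 log units; beyond the scatter) shows the benzyl amide losing potency, and an at least 4.1-fold higher number from compound 1 to compound 2 (0.61 log units; beyond the scatter) points the same way, whereas a step that the two limits leave unreadable from compound 2 to compound 3. Compound 4 `COc1ccc2c(=O)c(/C=C/C(=O)Nc3cccc(C)c3)coc2c1` differs from compound 3 in a single respect: 3-methylphenyl in place of 4-methylbenzyl on an amide-type nitrogen. This restores an aryl amide of the kind seen in compound 1, so a lower number is expected. Compound 4 is therefore estimated at 30000 nM, between 8000 nM and 100000 nM, which would mean an expected step of an at least 3.3-fold lower number from compound 3 to compound 4 (0.52 log units; beyond the scatter).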

Compound 4, half-maximal inhibitory concentration: > 100000 nM
Compound 4: only a limit was reported; the forecaster's own chance of this, stated with the estimate: 25%; middle value at least 3.3-fold (0.52 log units) from the limit.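

The aryl amide alone does not carry the reading in this assay, as 3-methylphenyl in place of 4-methylphenyl on the amide-type nitrogen gives an at least 4.1-fold higher number from compound 1 to compound 4 (0.61 log units; beyond the scatter). Among the four compounds shown, only compound 1 gives a reading rather than a limit, so the place of the methyl on the phenyl ring matters here. The steps among compound 2, compound 3 and compound 4 cannot be read, because all three values are the same limit: the limit of > 100000 nM in this assay, at which 3 of the 4 values shown sit.

As far as these compounds go, how far compound 4 lies from compound 1 remains unknown. From the compounds shown here alone, it also remains open whether a plain phenyl or a 4-methoxyphenyl on this nitrogen would give a reading.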